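From compound 1 to compound 4: expected clearance

A few compounds are considered here, and "the series" means these few. Any claim that something is new, unique, unknown or untested is made for them only; others in the source may bear on it.

Measured so far in an ADME assay on microsomes from liver (Homo sapiens) for pharmacokinetics; a higher number here means faster removal of the compound, a lower number slower removal (values follow)
Compound 1 `Cc1nn(C2COC2)cc1Nc1nc(N)c2c(C#N)c(N3CCC[C@H]3C)n(C)c2n1` gives 46.7 mL/min/kg
Compound 2 `Cc1nn(C2CCOC2)cc1Nc1nc(N)c2c(C#N)c(N3CCC[C@H]3C)n(C)c2n1` gives 76.7 mL/min/kg; 200 mL/min/kg (2 entries)
Compound 3 `Cc1c(Nc2nc(N)c3c(C#N)c(N4CCC[C@H]4C)n(C)c3n2)cnn1CC(C)(C)O` gives 30 mL/min/kg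

Compound 1 and compound 3 lie within the usual scatter of each other. Compound 2 has no single number (the several entries of compound 2 in this assay, 76.7 mL/min/kg; 200 mL/min/kg (2 entries)). Compound 4 (`C[C@@H]1CCCN1c1c(C#N)c2c(N)nc(Nc3cn(C)nc3C(F)(F)F)nc2n1C`) is unmeasured and differs from compound 1 as follows (1-methyl-3-(trifluoromethyl)-1H-pyrazol-4-yl in place of 3-methyl-1-(oxetan-3-yl)-1H-pyrazol-4-yl on a nitrogen on an aromatic ring). In words, 1-methyl-3-(trifluoromethyl)-1H-pyrazol-4-yl stands in place of 3-methyl-1-(oxetan-3-yl)-1H-pyrazol-4-yl on a nitrogen on an aromatic ring. Among the compounds with values here, no measured pair shows this exchange, and no step beyond the scatter is expected in this assay for it. The estimated step is a 1.1-fold higher number from compound 1 to compound 4 (0.03 log units; within the scatter) and stays within the scatter. Compound 4 is expected at 50 mL/min/kg with an estimated range from 22 mL/min/kg to 110 mL/min/kg for this measurement.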

Compound 4, clearance: 33.3 mL/min/kg
The estimate for compound 4 lay 1.5-fold (0.18 log units) above the measured number; measured number inside the range.
By their numbers in this assay, from the lowest: compounds 3, 4 and 1 (each within the scatter of the next).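

In this assay, 1-methyl-3-(trifluoromethyl)-1H-pyrazol-4-yl in place of 3-methyl-1-(oxetan-3-yl)-1H-pyrazol-4-yl on a nitrogen on an aromatic ring gives a 1.4-fold lower number from compound 1 to compound 4 (0.15 log units; within the scatter). At this position, a group with three fluorine atoms and without the four-membered non-aromatic ring therefore leaves clearance within the scatter of compound 1. Single entries in this read-out carry limited weight, as one compound shows a wide spread: the several entries of compound 2 in this assay, 76.7 mL/min/kg; 200 mL/min/kg (2 entries)

Which part of the exchange, if either, affects clearance remains open. So does whether an amine or a carboxylic acid at this position would stay within the scatter.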